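A few compounds are considered here, and "the series" means these few. Any claim that something is new, unique, unknown or untested is made for them only; others in the source may bear on it.

Compound 1 `CCOC(=O)Nc1sc(-c2ccc(Cl)cc2)c(-c2ccc(Cl)cc2)c1C(=O)NC1CC1`: 39800 nM
Compound 2 `COc1ccc(CNC(=O)c2c(N)sc(-c3ccc(Cl)cc3)c2-c2ccc(Cl)cc2)cc1`: 18200 nM
Compound 3 `CS(=O)(=O)Nc1sc(-c2ccc(Cl)cc2)c(-c2ccc(Cl)cc2)c1C(=O)NC1CC1`: "not determined" (no result reported)

In a functional assay on A549 cells (Homo sapiens) for inhibition, read by sulforhodamine B assay, with a stated time of 72 h (a higher number here means a weaker inhibitor, a lower number a stronger inhibitor), compound 2 gives 18200 nM, the lower of the two numbers reported in this assay; compound 1 gives 39800 nM, a higher number that lies beyond the usual scatter. Compound 3 has no result in this assay. Compound 4 `Nc1sc(-c2ccc(Cl)cc2)c(-c2ccc(Cl)cc2)c1C(=O)N1CCCCC1` differs from compound 2 in one place: piperidin-1-yl in place of (4-methoxybenzyl)amino on a carbonyl carbon. The shared core is unchanged. Within the data shown here, no measured pair shows the effect of such a change, so the size of the step is uncertain; a modest rise in the number, around the edge of the scatter, is expected. For compound 4 the estimate is 30000 nM, with a range from 9000 nM to 100000 nM, which would mean an expected step of a 1.6-fold higher number from compound 2 to compound 4 (0.22 log units; within the scatter).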

Compound 4, half-maximal inhibitory concentration: 4620 nM
Compound 4: the middle estimate sits 6.5-fold (0.81 log units) above what was measured; measured number outside the range, below it.
By their numbers in this assay, from the lowest: compound 4; then compound 2; then compound 1.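

Putting piperidin-1-yl on the carbonyl carbon in place of (4-methoxybenzyl)amino gives a 3.9-fold lower number from compound 2 to compound 4 (0.60 log units; beyond the scatter) in this assay. This place therefore responds to the amide group, and neither the aromatic ring nor the amide hydrogen of (4-methoxybenzyl)amino is needed to reach the lower number. Nothing at hand explains the step.

The compounds shown leave open whether the step follows from the piperidine ring itself or from the loss of the amide hydrogen. A morpholine or a dimethylamino group on the same carbonyl carbon, or a plain benzylamino group, would help separate these.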